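Removing the bromo group from compound 2: expected cytotoxicity

A few compounds are considered here, and "the series" means these few. Any claim that something is new, unique, unknown or untested is made for them only; others in the source may bear on it.

Three members of the series have numbers in an ADME assay on MDCK cells (Canis lupus familiaris) for cytotoxicity, read by microscopy, with a stated time of 48 h; on this read-out lower numbers stand for higher toxicity in this test and higher numbers for lower toxicity in this test. Compound 1 `C[C@H]1[C@H](NCc2cc(C3CC3)cs2)C[C@H]2C[C@@H]1C2(C)C` gives 25000 nM. Compound 2 `C[C@H]1[C@H](NCc2ccc(Br)s2)C[C@H]2C[C@@H]1C2(C)C` gives 43000 nM, the highest of the three numbers; its nearest neighbour is compound 1, within the scatter, while compound 3 `C=Cc1csc(CN[C@@H]2C[C@H]3C[C@@H]([C@H]2C)C3(C)C)c1` gives 6250 nM and stands furthest off, beyond the scatter. Among the measured compounds shown here, the only step measured between compounds differing in one place is a 4.0-fold lower number from compound 1 to compound 3 (0.60 log units; beyond the scatter), which concerns a different part of the structure and does not bear directly on the present change.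

Compound 4 `C[C@H]1[C@H](NCc2cccs2)C[C@H]2C[C@@H]1C2(C)C` is the next compound. It differs from compound 2 by hydrogen in place of bromo on an aromatic carbon. For the measured compounds named here, no measured pair carries out this kind of change, so there is no direct precedent, and the expectation is for no step beyond the scatter. Compound 4 is therefore expected to give 40000 nM in this assay, with a range from 15000 nM to 100000 nM. The step from compound 2 that this estimate means is expected to be a 1.1-fold lower number from compound 2 to compound 4 (0.03 log units; within the scatter).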

Compound 4, minimum cytotoxic concentration: 25000 nM
Compound 4: the middle estimate sits 1.6-fold (0.20 log units) above what was measured; the measured number falls inside the stated range.
By their numbers in this assay, from the lowest: compound 3; then compounds 1, 4 and 2 (each within the scatter of the next).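

In this assay, the bromo group on the aromatic carbon next to the ring sulfur can be replaced by hydrogen with no step beyond the scatter (a 1.7-fold lower number from compound 2 to compound 4 (0.24 log units; within the scatter)). The thiophen-2-yl compound also gives a hydrogen reference for the other groups: cyclopropyl does not separate from hydrogen (no change at the digits printed from compound 1 to compound 4 (within the scatter)), whereas vinyl does, beyond the scatter (a 4.0-fold higher number from compound 3 to compound 4 (0.60 log units; beyond the scatter)). Nothing measured here accounts for any of these steps.

From the compounds shown here alone, whether a methoxy group, an amine or a carboxylic acid on the carbon next to the ring sulfur would move the number beyond the scatter remains open. Also open, going by these compounds, is whether vinyl on that same carbon would give a step of the size seen between the vinyl compound and hydrogen.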